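Dibromo Hydroxyphenyl to Dimethyl Hydroxyphenyl on a Shared Core

This account rests on a few compounds, and the source may have more. Where it says the series, first, only, none or still open, it means among the compounds named here.

Compound 1 `CN(C)CCn1cnnc1-c1cc(Oc2ccc(NC(=O)N/N=C/c3ccc(Cl)cc3Cl)cc2F)ccn1`: 4760 nM
Compound 2 `COc1cc(/C=N/NC(=O)Nc2ccc(Oc3ccnc(-c4nncn4CCN(C)C)c3)c(F)c2)cc(OC)c1OC`: "not determined" (no result reported)
Compound 3 `CN(C)CCn1cnnc1-c1cc(Oc2ccc(NC(=O)N/N=C/c3cc(Br)c(O)c(Br)c3)cc2F)ccn1`: "not determined" (no result reported)

Three compounds with the same core were followed in an ADME assay on WI-38 cells (Homo sapiens) for cytotoxicity, read by MTT assay, with a stated time of 72 h; on this read-out higher numbers stand for weaker inhibition and lower numbers for stronger inhibition. Only compound 1 carries a number there, giving 4760 nM in this assay. In this assay compound 2 is recorded as "not determined" (no result reported). In this assay compound 3 is recorded as "not determined" (no result reported), so compound 3 stands among the entries that have no value, and nothing numerical places it relative to compound 1. Among the compounds with values here, no pair of measured compounds differs in a single place, so no measured step is available to guide the next change.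

Compound 4 `Cc1cc(/C=N/NC(=O)Nc2ccc(Oc3ccnc(-c4nncn4CCN(C)C)c3)c(F)c2)cc(C)c1O` is the next compound, and it differs from compound 3 in one place: 4-hydroxy-3,5-dimethylphenyl in place of 3,5-dibromo-4-hydroxyphenyl on a carbon with a double bond to nitrogen

Within the data shown here, with no step measured between any two compounds and no number for compound 3, there is no basis to expect a shift in either direction beyond the usual scatter of this assay. Among the measured compounds shown here, the only anchor is the value of compound 1 in this assay. Compound 4 is therefore expected to sit near that anchor, with an estimated value of 5000 nM and a range from 1500 nM to 16000 nM in this assay.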

Compound 4, half-maximal inhibitory concentration: 3610 nM
Estimate against measurement, compound 4: 1.4-fold (0.14 log units) above; the measured number falls inside the stated range.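

In this assay, within the data shown here, the swap of 2,4-dichlorophenyl for 4-hydroxy-3,5-dimethylphenyl on a carbon with a double bond to nitrogen gives a 1.3-fold lower number from compound 1 to compound 4 (0.12 log units; within the scatter) and provides the first measured comparison at this position. The two compounds therefore cannot be told apart on this read-out, even though the chlorine atoms on the ring are exchanged for a hydroxyl and two methyl groups. Compound 3 has no value, so its step to compound 4 cannot be read, and no supporting measurement bears on the result.

With a single readable step, the compounds shown cannot establish whether this position generally has little effect on the number or whether these two particular groups simply happen to give similar readings. From the compounds shown here alone, a phenyl ring carrying a carboxylic acid or an amine, or a longer chain in place of the ring at this position, could test how far the reading holds, while the effect of changes elsewhere on the shared core remains open.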